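The source may report more compounds than this note shows. Statements on the series, on what has been measured and on what is new or still open speak of the compounds shown alone.

Compound 3 `CO/C(O)=C1\C(C)=NC(C)=C(C(=O)OCC(C)C)C1c1ccccc1` gives 3.3 nM in a functional assay (muscle tissue) for inhibition, with Cavia porcellus as the target (a higher number here means a weaker inhibitor, a lower number a stronger inhibitor), and stands second highest of the three numbers in hand; compound 2 `CO/C(O)=C1\C(C)=NC(C)=C(C(=O)OCC(C)C)C1c1cccc(OC)c1` gives 7.1 nM and compound 1 `CO/C(O)=C1\C(C)=NC(C)=C(C(=O)OCC(C)C)C1c1cccc(C#N)c1` gives 0.27 nM. Compound 4 `CO/C(O)=C1\C(C)=NC(C)=C(C(=O)OCC(C)C)C1c1ccc(Cl)cc1` differs from compound 3 by chloro in place of hydrogen on an aromatic carbon. The measured steps all concern the same aromatic ring but other groups: a 12-fold higher number from compound 1 to compound 3 (1.09 log units; beyond the scatter) and a 26-fold higher number from compound 1 to compound 2 (1.42 log units; beyond the scatter) were large, while a 2.2-fold lower number from compound 2 to compound 3 (0.33 log units; beyond the scatter) was modest. Going by the values given here, no measured step places a chloro, and none involves the position para to a large group, so the bearing on this step is indirect. A step no larger than a 2.2-fold lower number from compound 2 to compound 3 (0.33 log units; beyond the scatter) is expected for compound 4, direction uncertain, that is a 1.5-fold higher number from compound 3 to compound 4 (0.18 log units; within the scatter). Compound 4 is estimated at 5 nM, with a range of 1.5 nM to 20 nM in this assay.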

Compound 4, half-maximal inhibitory concentration: 27 nM
Estimate against measurement, compound 4: 5.4-fold (0.73 log units) below; measured number outside the range, above it.
By their numbers in this assay, from the lowest: compound 1; then compound 3; then compound 2; then compound 4.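

In this assay, chloro para to a large group makes compound 4 the weakest of the four, with an 8.2-fold higher number from compound 3 to compound 4 (0.91 log units; beyond the scatter), a step larger than a 2.2-fold lower number from compound 2 to compound 3 (0.33 log units; beyond the scatter). Against the other substituted rings, the phenyl change gives a 3.8-fold higher number from compound 2 to compound 4 (0.58 log units; beyond the scatter) and a 100-fold higher number from compound 1 to compound 4 (2.00 log units; beyond the scatter), so this ring spans a wide range of numbers. Nothing available explains the step.

From the compounds shown here alone, whether the loss follows chloro itself or its place on the ring remains open. An amine or a carboxylic acid at this carbon, or chloro elsewhere on the ring, would separate the two.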